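The source may hold more compounds than are shown below. What is called first, only, known or untested is meant among the compounds shown, and "the series" means these compounds.

Measured so far:
Compound 1 `Cc1cccc(Nc2nc(C)c(C(=O)/C=C/c3ccccc3Cl)s2)c1` gives 22200 nM in a functional assay on PC-3 cells (Homo sapiens) for cytotoxicity, read by MTT assay; on this read-out higher numbers stand for weaker inhibition and lower numbers for stronger inhibition.
Compound 2 `Cc1ccccc1Nc1nc(C)c(C(=O)/C=C/c2ccccc2)s1` gives only a limit of the assay, > 25000 nM, in this assay.
Compound 3 `Cc1ccc(Nc2nc(C)c(C(=O)/C=C/c3ccccc3Cl)s2)cc1` also gives only a limit of the assay, > 25000 nM, in this assay.

Compound 3 therefore stands at the edge of what this assay can report, not at a number; the limit of > 25000 nM in this assay, at which 2 of the 3 values shown sit, describes where it sits. For the measured compounds named here, the only measured step that touches it is an at least 1.1-fold higher number from compound 1 to compound 3 (0.05 log units; that floor lies within the scatter), a move of the methyl around the same ring that did not bring a measurable number back.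

Compound 4 `Cc1ccccc1Nc1nc(C)c(C(=O)/C=C/c2ccccc2Cl)s1` differs from compound 3 in one place: 2-methylphenyl in place of 4-methylphenyl on a nitrogen on an aromatic ring. Going by the values given here, no measured step covers this particular swap on a core that already carries the chlorinated side chain. What can be said is that compound 2, which carries the same 2-methylphenyl group but lacks the chlorine, also returned only a limit in this assay.

With compound 3 at the limit and compound 2 at the limit, the expectation is that compound 4 also stays weak, with no step beyond the scatter. Compound 4 is estimated at 30000 nM, with a range from 15000 nM to 60000 nM. That estimate corresponds to an expected step that the limit leaves unreadable from compound 3 to compound 4.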

Compound 4, half-maximal inhibitory concentration: > 25000 nM
Compound 4: a limit, no number (the forecaster's own chance of this, stated with the estimate: 75%); the middle value does not contradict the limit.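

With compound 4 the methyl group has now been placed in three different ways on the ring attached to the nitrogen, all with the chloro group on the other aromatic ring, and none of them gives a clear gain in this assay. For the 2-methylphenyl group there is an at least 1.1-fold higher number from compound 1 to compound 4 (0.05 log units; that floor lies within the scatter), so compound 1 cannot be set apart from compound 4, even though only compound 1 returns a number. The steps linking compound 4 to compound 3 and to compound 2 cannot be read, as both ends of each are limits, and the series now sits mostly at one edge of what the assay can report: the limit of > 25000 nM in this assay, at which 3 of the 4 values shown sit.

As far as these compounds go, it remains open whether a different group in place of the methyl, such as an amine, a methoxy group or a carboxylic acid, would bring values into a readable range. Any real difference among the 2-methylphenyl, 3-methylphenyl and 4-methylphenyl groups also stays hidden, as would any effect of the chloro group on compounds at this limit.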